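A furan-2-yl swap at the assay limit

The source may hold more compounds than are shown below. What is called first, only, known or untested is meant among the compounds shown, and "the series" means these compounds.

In an ADME assay on J774.1 cells (Mus musculus) for cytotoxicity, read by resazurin assay, with a stated time of 48 h (on this read-out lower numbers stand for stronger inhibition and higher numbers for weaker inhibition), compound 3 `CCCCn1cc(C(=O)NCc2ccc(OC)c([N+](=O)[O-])c2)c(=O)c2cc(F)c(N3CCC(C(N)=O)CC3)cc21` gives > 100000 nM, which is a limit and not a number. Compound 2 `NC(=O)C1CCN(c2cc3c(cc2F)c(=O)c(C(=O)NCc2ccco2)cn3C2CC2)CC1` gives > 100000 nM, also a limit. Together they form (the limit of > 100000 nM in this assay, at which 2 of the 3 values shown sit). Compound 4 `CCCCn1cc(C(=O)NCc2ccco2)c(=O)c2cc(F)c(N3CCC(C(N)=O)CC3)cc21` arises through (furan-2-yl in place of 4-methoxy-3-nitrophenyl on a saturated chain carbon bound to an amide-type nitrogen). For the measured compounds named here, the only measured step, an at least 1.7-fold higher number from compound 1 to compound 2 (0.24 log units; that floor lies within the scatter), concerns the group on an aromatic nitrogen, so it sets no size for this change. Compound 1 `CCCn1cc(C(=O)NCc2ccco2)c(=O)c2cc(F)c(N3CCC(C(N)=O)CC3)cc21` carries the same furan-2-yl and gives 56900 nM, so a small move to a lower number is expected, perhaps none beyond the scatter. The expected step is an at least 1.4-fold lower number from compound 3 to compound 4 (0.15 log units; that floor lies within the scatter). For compound 4 the estimate is 70000 nM, with an expected range from 35000 nM to 100000 nM.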

Compound 4, half-maximal inhibitory concentration: 41400 nM
For compound 4 the middle estimate is 1.7-fold (0.23 log units) above the measured one; the range from low to high includes it.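

At this place, on a saturated chain carbon bound to an amide-type nitrogen, furan-2-yl in place of 4-methoxy-3-nitrophenyl gives an at least 2.4-fold lower number from compound 3 to compound 4 (0.38 log units; beyond the scatter) in this assay and so moves the read-out beyond the scatter. On the aromatic nitrogen, butyl in place of cyclopropyl gives an at least 2.4-fold lower number from compound 2 to compound 4 (0.38 log units; beyond the scatter) while a 1.4-fold lower number from compound 1 to compound 4 (0.14 log units; within the scatter) for the methyl that turns propyl into butyl leaves those two chains within the scatter. The two larger steps are floors and not sizes, since compound 2 and compound 3 each stand at a limit: the limit of > 100000 nM in this assay, at which 2 of the 4 values shown sit.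

As far as these compounds go, whether the nitro or the methoxy group carries the step from 4-methoxy-3-nitrophenyl stays open. So does the reading of a plain phenyl or thiophen-2-yl at this place, or of a pentyl chain on the aromatic nitrogen.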